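Amide variation on the shared core: the step to compound 4

A few compounds are considered here, and "the series" means these few. Any claim that something is new, unique, unknown or untested is made for them only; others in the source may bear on it.

Compound 1, `CN(C)CCC(=O)Nc1cccc(-c2nc3ccccc3s2)c1`: in an ADME assay on BJ cells (Homo sapiens) for inhibition, with a stated time of 72 h (a higher number here means that more compound is needed for the effect, a lower number that less compound is needed), compound 1 gives only a limit, > 25000 nM.
Compound 2, `CC(Cl)C(=O)Nc1cccc(-c2nc3ccccc3s2)c1`: in this assay compound 2 gives only a limit, > 25000 nM.
Compound 3, `CC(C)(CCl)C(=O)Nc1cccc(-c2nc3ccccc3s2)c1`: in this assay compound 3 gives only a limit, > 25000 nM.

Compound 3 therefore stands at a limit, not at a number, and so do both other compounds: the limit of > 25000 nM in this assay, at which 3 of the 3 values shown sit. Within the data shown here, the steps a step that the two limits leave unreadable from compound 1 to compound 2, a step that the two limits leave unreadable from compound 1 to compound 3 and a step that the two limits leave unreadable from compound 2 to compound 3 are all unreadable, so no measured step gives a size or a direction for the amide position. Compound 4, `O=C(Nc1cccc(-c2nc3ccccc3s2)c1)c1cnccc1Cl`, differs from compound 3 by 4-chloropyridin-3-yl in place of 1-(chloromethyl)-1-methylethyl on a carbonyl carbon. With every measured step unreadable, no change beyond the scatter can be expected in this assay in either direction. Compound 4 is expected near 25000 nM, between 5000 nM and 50000 nM. The expected step is a number no higher from compound 3 to compound 4 (the limit leaves the size open).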

Compound 4, half-maximal effective concentration: > 25000 nM
Compound 4: no number, only a limit; the forecaster's own chance of this, stated with the estimate: 70%; the middle value sits exactly at the limit.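

In this assay compound 4 gives only the limit > 25000 nM and so its steps from compound 1, compound 2 and compound 3 cannot be read. Left open is whether any group on the amide carbonyl changes this read-out at all: the limit of > 25000 nM in this assay, at which 4 of the 4 values shown sit.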